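Swapping a sulfonamide arm for a tertiary alcohol

The source may report more compounds than this note shows. Statements on the series, on what has been measured and on what is new or still open speak of the compounds shown alone.

Measured so far:
compound 1, `CCCC[S+]([O-])c1sc2nc(-c3nccs3)cc(-c3ccc(CNS(C)(=O)=O)cc3)c2c1N`, 4.6 nM
compound 2, `CCCC[S+]([O-])c1sc2nc(-c3nccn3C)nc(-c3ccccc3)c2c1N`, 3.7 nM

Both compounds were tested in an assay for inhibition of 15-hydroxyprostaglandin dehydrogenase [NAD(+)] (Homo sapiens), read by fluorescence, with a stated time of 15 min, in the presence of a further agent that is not named here; on this read-out higher numbers stand for weaker inhibition and lower numbers for stronger inhibition. Compound 1 gives 4.6 nM and compound 2 gives 3.7 nM; the two numbers sit within the usual scatter of each other, so neither can be called the stronger inhibitor on this evidence. Compound 3, `CCCC[S+]([O-])c1sc2nc(-c3nccs3)cc(-c3ccc(C(C)(C)O)cc3)c2c1N`, has not yet been measured. It shares the core of compound 1 and differs from it in one place: 1-hydroxy-1-methylethyl in place of (methanesulfonamido)methyl on an aromatic carbon. The entering group keeps one hydrogen-bond donor and one acceptor, so the change is modest in size. Among the compounds with values here, with no measured pair of this kind to lean on, the step of a 1.5-fold higher number from compound 1 to compound 3 (0.18 log units; within the scatter) is expected to stay small, at most a slight weakening beyond the scatter. Compound 3 is therefore estimated at 7 nM, in a range from 2.5 nM to 20 nM.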

Compound 3, half-maximal inhibitory concentration: 3.6 nM
The estimate for compound 3 lay 1.9-fold (0.29 log units) above the measured number, and the stated range covers the measured number.
By their numbers in this assay, from the lowest: compounds 3, 2 and 1 (each within the scatter of the next).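

Placing 1-hydroxy-1-methylethyl where (methanesulfonamido)methyl stood on the aromatic carbon gives a 1.3-fold lower number from compound 1 to compound 3 (0.11 log units; within the scatter) in this assay, so the two compounds cannot be told apart on this read-out. At this position, para to a large group, a smaller entering group with no sulfur or nitrogen therefore gives a number indistinguishable from that of the sulfonamide arm, at least for this pair. Nothing measured here explains why the two groups read alike.

As far as these compounds go, both groups carry one hydrogen-bond donor, so it remains open how a group without one, such as methoxy or a plain methyl, would read at this position. From the compounds shown here alone, the outcome with an amine or a carboxylic acid in the same place is also open.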